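Phenyl Extension and Cytotoxicity in Two Related Cores

The source may hold more compounds than are shown below. What is called first, only, known or untested is meant among the compounds shown, and "the series" means these compounds.

Measured compounds:
- Compound 1 `CN1Cc2ccc(OCc3ccccc3)cc2[C@@H](O)C1`: > 100000 nM in an ADME assay on Vero cells (Chlorocebus sabaeus) for cytotoxicity, read by sulforhodamine B assay, with a stated time of 72 h (on this read-out higher numbers stand for weaker inhibition and lower numbers for stronger inhibition), a limit of the assay.
- Compound 2 `CN1Cc2ccc(OCc3ccc(-c4ccccc4)cc3)cc2[C@@H](O)C1`: 23000 nM in this assay.
- Compound 3 `CN1CCc2cc(Oc3ccccc3)ccc2C1`: > 100000 nM in this assay, a limit of the assay.

Compound 1 gives only a limit in this assay. Compound 2 gives a number, and the change between them, (phenyl in place of hydrogen on an aromatic carbon), produces an at least 4.3-fold lower number from compound 1 to compound 2 (0.63 log units; beyond the scatter). Compound 3 also gives only a limit in this assay. The difference between the core of compound 1 and the core of compound 3 is not broken down here.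

Compound 4 `CN1CCc2cc(Oc3ccc(-c4ccccc4)cc3)ccc2C1` has not been measured. It differs from compound 3 by phenyl in place of hydrogen on an aromatic carbon, the same change as that from compound 1 to compound 2. For the measured compounds named here, two of the three values so far sit at the limit of > 100000 nM in this assay, at which 2 of the 3 values shown sit, so the size of the earlier step is known only as a lower bound.

In this assay compound 4 is expected to show an at least 3.3-fold lower number from compound 3 to compound 4 (0.52 log units; beyond the scatter), resting on the step of an at least 4.3-fold lower number from compound 1 to compound 2 (0.63 log units; beyond the scatter) seen for the same change. The estimate for compound 4 is 30000 nM, with a range from 10000 nM to 100000 nM.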

Compound 4, half-maximal inhibitory concentration: 22300 nM
Compound 4: middle estimate off by 1.3-fold (0.13 log units), on the high side; the measured number falls inside the stated range.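

In this assay, phenyl in place of hydrogen on an aromatic carbon, para to a large group, gives an at least 4.4-fold lower number from compound 3 to compound 4 (0.65 log units; beyond the scatter), so the lower number seen on the core of compound 1 appears again on the core of compound 3. Set side by side, the two steps run the same way, but their sizes cannot be told apart: the same change on two cores in this assay, an at least 4.3-fold lower number (0.63 log units; beyond the scatter) from compound 1 to compound 2 and an at least 4.4-fold lower number (0.65 log units; beyond the scatter) from compound 3 to compound 4; the limit leaves it open whether they differ. Compound 1 and compound 3 each give only a limit of the assay, so both steps are lower bounds, and the carry-over is shown on these two cores alone: the limit of > 100000 nM in this assay, at which 2 of the 4 values shown sit.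

The compounds shown leave open whether an amine, a carboxylic acid or a longer chain entering at the same place would lower the number as phenyl does. They also leave open whether the phenyl step would hold on any further core, and how large it is on a starting compound that gives a number rather than a limit.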